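This account rests on a few compounds, and the source may have more. Where it says the series, first, only, none or still open, it means among the compounds named here.

Measured so far in a functional assay on BC1 cells (Homo sapiens) for cytotoxicity, read by sulforhodamine B assay, with a stated time of 72 h; a higher number here means that more compound is needed for the effect, a lower number that less compound is needed:

Compound 1 `CCCC[C@H](OC(C)=O)[C@@H](O)[C@H](O)[C@@H]1OC(=O)C=C[C@@H]1OC(C)=O` gives 9.9 ug/mL.
Compound 2 `CCCC[C@@H](/C=C\[C@@H]1OC(=O)C=C[C@@H]1O)OC(C)=O` gives 2 ug/mL.
Compound 3 `CC(=O)O[C@H](/C=C\[C@H]1CC=CC(=O)O1)C[C@@H](OC(C)=O)[C@H](C)OC(C)=O` gives 2.4 ug/mL.

Compound 2 has the lowest of the three numbers in this assay, meaning the least compound is needed for the effect. Its nearest neighbour is compound 3, whose number is only slightly higher; that gap lies within the usual scatter of repeated measurements, so the two cannot be told apart. Compound 1 sits furthest away, with a gap that is well beyond the scatter.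

Compound 4 `CCCC[C@@H](/C=C\[C@@H]1OC(=O)C=C[C@@H]1OC(C)=O)OC(C)=O` has not yet been measured. It differs from compound 2 in one place: acetyl in place of hydrogen on an oxygen on a saturated carbon. Cut one bond further out, the change reads hydroxy to acetoxy.

Within the data shown here, no pair of measured compounds differs in exactly this way, so no measured step shows what to expect. Compound 3, which carries acetyl groups on all of its oxygens, gives 2.4 ug/mL, close to compound 2, while compound 1, with free hydroxy groups next to its acetyl groups, gives 9.9 ug/mL. Neither is a clean one-place comparison, so these values only hint that the change may matter little. The step from compound 2 to compound 4 in this assay is therefore expected to be small, a 1.3-fold higher number from compound 2 to compound 4 (0.10 log units; within the scatter), not beyond the scatter. Compound 4 is estimated at 2.5 ug/mL, with a range from 1 ug/mL to 7 ug/mL.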

Compound 4, concentration for half-maximal effect: 1 ug/mL
Beside the measured number, compound 4's estimate is 2.5-fold (0.40 log units) above it; measured number inside the range.
By their numbers in this assay, from the lowest: compounds 4, 2 and 3 (each within the scatter of the next, the first and the last beyond it); then compound 1.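

Among these compounds, measured in this assay, this is the first direct one-place comparison at this position: a 2.0-fold lower number from compound 2 to compound 4 (0.30 log units; within the scatter). The change from hydroxy to acetoxy, on an oxygen on a saturated carbon, therefore leaves the two compounds indistinguishable, which shows that a free hydroxy at this position is not required for the effect in this pair. No measurement shown here offers an explanation for this result.

The compounds shown leave open whether a different group at this position, such as a methoxy group, a longer ester such as benzoyloxy, or an amine, would also give so small a step. They also leave open whether the same change elsewhere on the shared core would behave in the same way.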